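Swapping the terminal amine on a three-carbon ether chain

The compounds below may be only part of what the source reports. "The series", "measured", "known", "first", "only" and "open" are said of these compounds alone.

For the measured compounds named here, in a functional assay on A549 cells (Homo sapiens) for antiproliferative activity, read by MTT assay, with a stated time of 72 h (a lower number here means a stronger inhibitor, a higher number a weaker inhibitor), compound 2 `CCOC(=O)C1CCN(CCCOc2cc3ncnc(Nc4ccc(C#N)cc4)c3cc2OC)CC1` gives 89900 nM, the higher of the two numbers measured so far. Going by the values given here, its neighbour, compound 1 `COc1cc2c(Nc3ccc(C#N)cc3)ncnc2cc1OCCCN1CCCCC1`, gives 23500 nM in this assay, and the one step between them, a 3.8-fold higher number from compound 1 to compound 2 (0.58 log units; beyond the scatter), shows that adding the ester group weakened the compound. Compound 3 `COc1cc2c(Nc3ccc(C#N)cc3)ncnc2cc1OCCCN1CCN(c2ccncc2)CC1` has not been measured. It differs from compound 2 by 4-(pyridin-4-yl)piperazin-1-yl in place of 4-(ethoxycarbonyl)piperidin-1-yl on a saturated chain carbon, three bonds along the chain from an oxygen on an aromatic ring. Among the compounds with values here, no measured step covers this exchange; the only step on record concerns the same position and shows that the unsubstituted amine of compound 1 gave the lower number. Compound 3 also lacks the ethoxycarbonyl group, so the number is expected to fall back toward that of compound 1, giving an estimated step of a 3.0-fold lower number from compound 2 to compound 3 (0.48 log units; beyond the scatter). Compound 3 is therefore estimated at 30000 nM in this assay, within a range of 10000 nM to 90000 nM.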

Compound 3, half-maximal inhibitory concentration: 25500 nM
Estimate against measurement, compound 3: 1.2-fold (0.07 log units) above, within the range that was stated.
By their numbers in this assay, from the lowest: compounds 1 and 3 (each within the scatter of the next); then compound 2.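

In this assay, the exchange of 4-(ethoxycarbonyl)piperidin-1-yl for 4-(pyridin-4-yl)piperazin-1-yl gave a 3.5-fold lower number from compound 2 to compound 3 (0.55 log units; beyond the scatter), so a substituted group at this place on the chain does not by itself bring the higher number seen for compound 2. Placing 4-(pyridin-4-yl)piperazin-1-yl in place of piperidin-1-yl gave a 1.1-fold higher number from compound 1 to compound 3 (0.04 log units; within the scatter), which shows that this place takes the added aromatic ring with no change beyond the scatter. No measurement bears on the reason for these results.

The compounds shown leave open whether a carboxylic acid or an amide in place of the ethoxycarbonyl group would keep the higher number of compound 2. As far as these compounds go, how morpholine in place of piperidin-1-yl, or a longer chain, would read in this assay also remains open.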